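The compounds below may be only part of what the source reports. "The series", "measured", "known", "first", "only" and "open" are said of these compounds alone.

Series notes. Compound 1 `O=C1C(=O)N(Cc2cn(CC(=O)N3CCN(c4cc5c(cc4F)c(=O)c(C(=O)O)cn5C4CC4)CC3)nn2)c2c(F)cccc21` gives 8 ug/mL in an ADME assay on Vero cells (Chlorocebus sabaeus) for cytotoxicity; a higher number here means that more compound is tolerated, a lower number that less compound is tolerated. Compound 2 `O=C1C(=O)N(Cc2cn(CC(=O)N3CCN(c4cc5c(cc4F)c(=O)c(C(=O)O)cn5C4CC4)CC3)nn2)c2ccccc21` gives 16 ug/mL in this assay. The change between these two is hydrogen in place of fluoro on an aromatic carbon, and the step it made is a 2.0-fold higher number from compound 1 to compound 2 (0.30 log units; within the scatter). Compound 3 `CO/N=C1/C(=O)N(Cc2cn(CC(=O)N3CCN(c4cc5c(cc4F)c(=O)c(C(=O)O)cn5C4CC4)CC3)nn2)c2ccc(F)cc21` gives 64 ug/mL in this assay, the highest of the three values; the difference between the core of compound 3 and the core of compound 1 is not broken down here. Compound 4 `CO/N=C1/C(=O)N(Cc2cn(CC(=O)N3CCN(c4cc5c(cc4F)c(=O)c(C(=O)O)cn5C4CC4)CC3)nn2)c2ccccc21` is not yet measured and differs from compound 3 by hydrogen in place of fluoro on an aromatic carbon. This is the same kind of change as from compound 1 to compound 2, not the same: there the place was ortho to a fused ring and meta to a fused ring, here it is meta to a fused ring and para to a fused ring. Since the earlier step of a 2.0-fold higher number from compound 1 to compound 2 (0.30 log units; within the scatter) lay within the scatter, compound 4 is expected to give 90 ug/mL, from 45 ug/mL to 180 ug/mL, and the expected step of a 1.4-fold higher number from compound 3 to compound 4 (0.15 log units; within the scatter) is small.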

Compound 4, half-maximal cytotoxic concentration: 128 ug/mL
The estimate for compound 4 lay 1.4-fold (0.15 log units) below the measured number, and the stated range covers the measured number.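

Hydrogen in place of fluoro on an aromatic carbon gives, in this assay, a 2.0-fold higher number from compound 3 to compound 4 (0.30 log units; within the scatter). The change reads the same on both cores: the same change on two cores in this assay, a 2.0-fold higher number (0.30 log units; within the scatter) from compound 1 to compound 2 and a 2.0-fold higher number (0.30 log units; within the scatter) from compound 3 to compound 4, 1.0-fold (0.00 log units) apart, within the scatter of two such steps. On these two cores the change carries over without a step beyond the scatter, but neither step on its own separates an effect of the fluoro from the scatter, and the two steps stand at different places on the ring, which leaves place and core unseparated.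

Still open, as far as these compounds go, is whether a chloro group, a methoxy group or an amine on that aromatic carbon would give a step beyond the scatter in this assay. Also open, from the compounds shown here alone, is whether the same change holds on a third core.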